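The compounds below may be only part of what the source reports. "The series", "measured", "known", "first", "only" and "open" are said of these compounds alone.

Going by the values given here, compound 2, `O=C(/C=C/c1ccc(O)cc1)c1c(O)cccc1OCCC1CCCC1`, is the only member of this small set to give a number in an assay on THP-1 cells for inhibition of nuclear factor NF-kappa-B complex (Homo sapiens), with stated times of 2 h and 16 h; on this read-out higher numbers stand for weaker inhibition and lower numbers for stronger inhibition: compound 2 gives 18000 nM. Compound 1, `CC(C)=CCOc1cccc(O)c1C(=O)/C=C/c1ccc(O)cc1`, gives only a limit of the assay, > 30000 nM. Compound 3, `CC(C)(C)CCOc1cccc(O)c1C(=O)CCc1ccc(O)cc1`, likewise gives only a limit, > 30000 nM. Compound 2 therefore stands alone with a number, while two of the three values sit at the limit of > 30000 nM in this assay, at which 2 of the 3 values shown sit. Among the compounds with values here, the single measured step, an at least 1.6-fold lower number from compound 1 to compound 2 (0.22 log units; that floor lies within the scatter), came with cyclopentylmethyl in place of 2-methylprop-1-en-1-yl on a saturated chain carbon bound to an oxygen on an aromatic ring, and its floor lies within the scatter.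

Compound 4, `CC(C)(C)CCOc1cccc(O)c1C(=O)/C=C/c1ccc(O)cc1`, differs from compound 2 by tert-butyl in place of cyclopentyl on a saturated chain carbon, two bonds along the chain from an oxygen on an aromatic ring; read one bond further out, 2-cyclopentylethoxy becomes 3,3-dimethylbutoxy. Within the data shown here, the one step measured in this region was small, so the expected step, a 1.4-fold higher number from compound 2 to compound 4 (0.14 log units; within the scatter), is not expected to exceed the scatter. Compound 3 carries the same 3,3-dimethylbutoxy chain on a saturated linker and shows only a limit, > 30000 nM, so the estimate leans toward weaker inhibition. Compound 4 is estimated at 25000 nM, within 12000 nM to 60000 nM.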

Compound 4, half-maximal inhibitory concentration: 3000 nM
The estimate for compound 4 lay 8.3-fold (0.92 log units) above the measured number; the whole stated range lies above it.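

In this assay, going by these compounds alone, the far end of the ether chain proves able to move the number beyond the scatter, which the one earlier step could not show. Tert-butyl in place of cyclopentyl, on a saturated chain carbon two bonds along the chain from an oxygen on an aromatic ring, came with a 6.0-fold lower number from compound 2 to compound 4 (0.78 log units; beyond the scatter), so the ring of compound 2 is not needed for inhibition here, and the open tert-butyl end does better. Neopentyl in place of 2-methylprop-1-en-1-yl on a saturated chain carbon bound to an oxygen on an aromatic ring came with an at least 10-fold lower number from compound 1 to compound 4 (1.00 log units; beyond the scatter), which confirms the gain against a second chain end.

From the compounds shown here alone, whether a longer chain or an amine at the chain end would lower the number further remains open. The true size of any step involving a limit also stays unknown, and such limits are common in this small set: the limit of > 30000 nM in this assay, at which 2 of the 4 values shown sit.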